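Flipping one stereocentre in compound 3

This account rests on a few compounds, and the source may have more. Where it says the series, first, only, none or still open, it means among the compounds named here.

In an ADME assay on MDCK cells (Canis lupus familiaris) for permeability, read by LC-MS, with a stated time of 90 min, tested at 2 uM (a lower number here means that the compound crosses the layer more slowly, a higher number that the compound crosses the layer faster), compound 3 `Cc1cc(C)c(CN2CCc3c(Cl)cc([C@H](C)CO)c(Cl)c3C2=O)c(=O)[nH]1` gives 12.4 10^-6 cm/s as its reading. That is the higher of the two single numbers here, since compound 2 `Cc1cc(C)c(CN2CCc3c(Cl)cc([C@H](CO)[C@H]4CCCO4)c(Cl)c3C2=O)c(=O)[nH]1` gives 4.1 10^-6 cm/s in this assay as well. Compound 1 `COC(c1cc(Cl)c2c(c1Cl)C(=O)N(Cc1c(C)cc(C)[nH]c1=O)CC2)C1CCOCC1` has two readings and gives 13.3 10^-6 cm/s; 16.5 10^-6 cm/s (2 entries) on those occasions. The spread within the several entries of compound 1 in this assay, 13.3 10^-6 cm/s; 16.5 10^-6 cm/s (2 entries) shows how far two readings of one compound can lie apart.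

Compound 4 `Cc1cc(C)c(CN2CCc3c(Cl)cc([C@@H](C)CO)c(Cl)c3C2=O)c(=O)[nH]1` is related to compound 3 in a subtler way (the two compounds have the same atoms and bonds and differ only in configuration as drawn: 1 of 1 stereo elements differ; a stereocentre at a saturated chain carbon is drawn S in compound 3 and R in compound 4). Nothing leaves and nothing enters, so only the drawn configuration at that one chain carbon changes.

Within the data shown here, the one measured step that comes close is a 3.0-fold higher number from compound 2 to compound 3 (0.48 log units; beyond the scatter) and it is modest, though beyond the scatter. That step replaced a whole group, however, so it is a poor guide to a change that keeps every atom and bond. Among the measured compounds shown here, no measured pair here tests a flipped stereocentre on its own. The expectation is therefore no step beyond the scatter, and the estimated change is a 1.0-fold lower number from compound 3 to compound 4 (0.01 log units; within the scatter) at most a small drift. In this assay compound 4 is expected near 12 10^-6 cm/s with an estimated range (7 10^-6 cm/s to 19 10^-6 cm/s).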

Compound 4, apparent permeability: 15 10^-6 cm/s
Beside the measured number, compound 4's estimate is 1.3-fold (0.10 log units) below it, and the stated range covers the measured number.
By their numbers in this assay, from the lowest: compound 2; then compounds 3 and 4 (each within the scatter of the next).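

Swapping the drawn configuration at this saturated chain carbon gives a 1.2-fold higher number from compound 3 to compound 4 (0.08 log units; within the scatter), the first direct test of a stereocentre on its own in this assay. A gap of this size is no greater than the gap that two readings of a single compound can show: the several entries of compound 1 in this assay, 13.3 10^-6 cm/s; 16.5 10^-6 cm/s (2 entries). The larger step at this position also appears with either drawn configuration of the methyl compounds, as methyl in place of oxolan-2-yl gives a 3.7-fold higher number from compound 2 to compound 4 (0.56 log units; beyond the scatter), which sits alongside the earlier 3.0-fold higher number from compound 2 to compound 3 (0.48 log units; beyond the scatter).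

All of this rests on one pair of mirror-drawn configurations with a methyl group on the chain carbon, so the compounds shown leave open whether the same configurational swap would stay within the scatter with oxolan-2-yl there instead. They also leave open how the reading in this assay would respond to an amine or a carboxylic acid in place of the hydroxyl group on the chain, and whether the two configurations would stay this close with either of those groups present.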